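The source may hold more compounds than are shown below. What is called first, only, known or untested is meant among the compounds shown, and "the series" means these compounds.

Measured so far in a functional assay on KB cells (Homo sapiens) for inhibition, read by MTT assay, with a stated time of 24 h, tested at 1 ug/mL; on this read-out higher numbers stand for more inhibition of growth at the one concentration tested and lower numbers for less inhibition of growth:
- compound 1 `O=C(CCCCC1CCSS1)Nc1ccccc1Cl` gives "not active" (no number reported)
- compound 2 `O=C(CCCCC1CCSS1)Nc1cccc(C(F)(F)F)c1` gives 9.5%
- compound 3 `O=C(CCCCC1CCSS1)Nc1ccc(Br)cn1` gives 4.33%

Compound 1 has no number to stand on. In this assay compound 1 is recorded only as "not active" (no number reported), so it offers no numerical baseline for a step. Compound 2 with 9.5% and compound 3 with 4.33% lie within the usual scatter of each other, and both show only slight inhibition of growth. All three measured compounds carry the same five-membered non-aromatic ring.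

Compound 4 `O=C(CCCCC(S)CCS)Nc1ccccc1Cl` keeps the rest of compound 1 and changes in one place: a group of 5 heavy atoms (3 carbon, 2 sulfur; no ring) in place of a group of 5 heavy atoms (3 carbon, 2 sulfur; one five-membered non-aromatic ring with 2 hetero atoms), on a saturated chain carbon, four bonds along the chain from a carbonyl carbon. The ring is opened, and 1,3-disulfanylpropyl stands in its place. Among the measured compounds shown here, no measured pair shows what such a change does, so any expectation here remains loose. Starting from compound 1 with "not active" (no number reported), a change in this assay could only be read upward. The step expected is small, probably not far beyond the scatter, with a modest chance of a larger rise. The estimated inhibition for compound 4 is 10%, with an expected range from 0% to 35%.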

Compound 4, percent growth inhibition at one concentration: "not active" (no number reported)
Nothing numeric was reported for compound 4; the estimate stays without a comparison.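

Compound 1 and compound 4 are both recorded without a number in this assay, so no step can be read between them. No evidence shown here bears on this result. The compounds shown leave open whether 1,3-disulfanylpropyl in place of the ring changes growth inhibition at all.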